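Shifting the Hydroxy Group: From Compound 2 to Compound 3

The compounds below may be only part of what the source reports. "The series", "measured", "known", "first", "only" and "open" are said of these compounds alone.

Compound 2 `COc1ccc(C/C=C/CCCCc2ccc(O)cc2)cc1` gives 47000 nM in a functional assay on RAW264.7 cells (Mus musculus) for inhibition, read by Griess assay, with stated times of 1 h and 24 h; a lower number here means a stronger inhibitor, a higher number a weaker inhibitor. Going by the values given here, that is the highest of the two numbers measured so far; its nearest neighbour is compound 1 `COc1ccc(C/C=C/CCCCc2ccc(O)c(O)c2)cc1`, which in this assay gives 25100 nM, and the step of a 1.9-fold higher number from compound 1 to compound 2 (0.27 log units; within the scatter) lies within the scatter. Compound 3 `COc1ccc(C/C=C/CCCCc2cccc(O)c2)cc1` has not yet been measured. It differs from compound 2 in one place: 3-hydroxyphenyl in place of 4-hydroxyphenyl on a saturated chain carbon, four bonds along the chain from a double-bonded chain carbon. Among the compounds with values here, the only measured step, a 1.9-fold higher number from compound 1 to compound 2 (0.27 log units; within the scatter), removes a hydroxy group altogether rather than moving it, so it does not bear directly on this change, and no measured pair shows what a shift of the hydroxy group around its ring does. With nothing in the data pointing in either direction, the step of a 1.0-fold lower number from compound 2 to compound 3 (0.02 log units; within the scatter) is expected to stay within the scatter. Compound 3 is therefore estimated at 45000 nM in this assay, with a range from 18000 nM to 110000 nM, and the true number could sit on either side of compound 2.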

Compound 3, half-maximal inhibitory concentration: 47000 nM
For compound 3 the middle estimate is 1.0-fold (0.02 log units) below the measured one; low and high end bracket the measured number.
By their numbers in this assay, from the lowest: compounds 1, 2 and 3 (each within the scatter of the next).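

In this assay, moving the hydroxy group around its ring gives no change at the digits printed from compound 2 to compound 3 (within the scatter), so at this place, on a saturated chain carbon four bonds along the chain from a double-bonded chain carbon, 3-hydroxyphenyl and 4-hydroxyphenyl cannot be told apart. The new comparison with compound 1, a 1.9-fold higher number from compound 1 to compound 3 (0.27 log units; within the scatter), also stays within the scatter, as does the earlier 1.9-fold higher number from compound 1 to compound 2 (0.27 log units; within the scatter), so neither of the two rings with a single hydroxy group separates from the ring of compound 1. Among these compounds, then, neither the place of the hydroxy group nor the loss of one of the two hydroxy groups of compound 1 gives a step beyond the scatter. No supporting measurement is available to explain this result.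

Going by these compounds, what a bare phenyl ring, a methoxy group, an amine or a carboxylic acid would do on this ring remains open. So does the effect of a longer chain between the two rings of the shared core, which these three compounds cannot address.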